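Biphenyl for tert-butyl in a bis(trifluoromethyl)benzenesulfonamide series

This account rests on a few compounds, and the source may have more. Where it says the series, first, only, none or still open, it means among the compounds named here.

Compound 1 `CC(C)(C)c1ccc(CNCCCNS(=O)(=O)c2cc(C(F)(F)F)cc(C(F)(F)F)c2)cc1` gives 2300 nM in a functional assay on MIA PaCa-2 cells (Homo sapiens) for inhibition, read by MTT assay, with a stated time of 72 h (on this read-out lower numbers stand for stronger inhibition of growth and higher numbers for weaker inhibition of growth), the lowest of the three numbers shown. Compound 3 `O=S(=O)(NCCCNCC1COc2ccccc2O1)c1cc(C(F)(F)F)cc(C(F)(F)F)c1` gives 2600 nM, and compound 2 `O=S(=O)(NCCCNCc1ccc(Cl)c(C(F)(F)F)c1)c1cc(C(F)(F)F)cc(C(F)(F)F)c1` gives 7400 nM. The step of a 1.1-fold higher number from compound 1 to compound 3 (0.05 log units; within the scatter) lies within the scatter, while a 3.2-fold higher number from compound 1 to compound 2 (0.51 log units; beyond the scatter) and a 2.8-fold lower number from compound 2 to compound 3 (0.45 log units; beyond the scatter) are modest. Compound 4 `O=S(=O)(NCCCNCc1ccc(-c2ccccc2)cc1)c1cc(C(F)(F)F)cc(C(F)(F)F)c1` differs from compound 1 by phenyl in place of tert-butyl on an aromatic carbon. Going by the values given here, no measured step replaces tert-butyl by phenyl, and the only step beyond the scatter, a 3.2-fold higher number from compound 1 to compound 2 (0.51 log units; beyond the scatter), exchanged the whole ring. Compound 4 is therefore expected to give 2500 nM, within a range from 1000 nM to 6500 nM. Compound 4 is thus estimated to show a step of a 1.1-fold higher number from compound 1 to compound 4 (0.04 log units; within the scatter), likely within the scatter.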

Compound 4, concentration for 50% growth inhibition: 2400 nM
Compound 4: middle estimate off by 1.0-fold (0.02 log units), on the high side; the range from low to high includes it.
By their numbers in this assay, from the lowest: compounds 1, 4 and 3 (each within the scatter of the next); then compound 2.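

The exchange of tert-butyl for phenyl gives a 1.0-fold higher number from compound 1 to compound 4 (0.02 log units; within the scatter) in this assay. Unlike the earlier steps, which exchanged the whole ring, this one alters only the group on the aromatic carbon, and it shows that a six-membered aromatic ring of carbon only can stand there in place of tert-butyl with the number staying within the scatter. Nothing given here accounts for this result. The compounds shown leave open whether an amine or a carboxylic acid on this aromatic carbon would hold the number in the same range.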